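Ester variation on the dihydropyrimidinone-type core: tert-butyl to cyclopentyl

This account rests on a few compounds, and the source may have more. Where it says the series, first, only, none or still open, it means among the compounds named here.

Three compounds of this series have numbers in an assay on membranes from HEK293 cells for displacement of a labelled ligand from adenosine receptor A2b (Homo sapiens), read by scintillation counting, with a stated time of 30 min (a lower number here means a stronger inhibitor, a higher number a weaker inhibitor), so far. Compound 1 `CC1=C(C(=O)OC(C)(C)C)C(c2ccoc2)NC(=O)N1` gives 4440 nM, the highest of the three. Compound 3 `CC1=C(C(=O)CC(C)C)C(c2ccco2)NC(=O)N1` differs from compound 1 in several places, and compound 3 gives 240 nM. Compound 2 `CC1=C(C(=O)OC(C)C)[C@@H](c2ccco2)NC(=S)N1` likewise differs from compound 1 in several places, and compound 2 gives 6.3 nM. Compound 1 thus stands at the weak end of what has been measured, with compound 3 nearest and compound 2 furthest away, both gaps beyond the scatter. Since compounds 1, 2 and 3 differ from one another in several places, none of these gaps can be tied to a single change.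

Compound 4 `CC1=C(C(=O)OC2CCCC2)C(c2ccoc2)NC(=O)N1` is the next entry and differs from compound 1 in one place: cyclopentyl in place of tert-butyl on an oxygen next to a carbonyl group. No measured pair in the set isolates this kind of change, so the expectation rests on the two groups being of comparable make-up as described above. A small step is expected, at most a modest lowering and possibly none beyond the scatter; the step from compound 1 to compound 4 is estimated as a 1.5-fold lower number from compound 1 to compound 4 (0.17 log units; within the scatter). Compound 4 is expected to give about 3000 nM in this assay, with a range from 800 nM to 10000 nM.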

Compound 4, inhibition constant: 1010 nM
Beside the measured number, compound 4's estimate is 3.0-fold (0.47 log units) above it; the range from low to high includes it.
By their numbers in this assay, from the lowest: compound 2; then compound 3; then compound 4; then compound 1.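

In this assay the group on the ester oxygen proves to be a position that moves the number on its own: cyclopentyl in place of tert-butyl on an oxygen next to a carbonyl group gives a 4.4-fold lower number from compound 1 to compound 4 (0.64 log units; beyond the scatter), with the rest of the structure held fixed. Going by these compounds alone, this is the first comparison that ties a change in the number to a single place, which the earlier compounds, differing from one another in several places, could not do. The step is modest but beyond the scatter, so even an exchange between two all-carbon groups with no hydrogen-bond donors or acceptors counts here, though nothing measured alongside this pair accounts for it.

A single pair cannot separate the presence of the ring from the extra carbon or from the loss of the tert-butyl shape, and cyclobutyl, cyclohexyl or a straight butyl chain on the same oxygen would each bear on that. From the compounds shown here alone, whether the step carries over to a compound with the thiocarbonyl of compound 2 also remains open.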